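Carbamate nitrogen substituent in a corticotropin-releasing factor series

A few compounds are considered here, and "the series" means these few. Any claim that something is new, unique, unknown or untested is made for them only; others in the source may bear on it.

Measured so far:
compound 1, `COc1nc(C)c(Nc2nc(Cl)cn([C@H](COC(=O)Nc3ccccc3Cl)C3CC3)c2=O)cc1C`: 1.5 nM
compound 2, `COc1nc(C)c(Nc2nc(Cl)cn([C@H](COC(=O)Nc3ccc(Cl)cc3Cl)C3CC3)c2=O)cc1C`: 1.7 nM

In an assay on frontal cortex for displacement of a labelled ligand from corticotropin-releasing factor receptor 1 (Rattus norvegicus), with a stated time of 2 h (a higher number here means a weaker inhibitor, a lower number a stronger inhibitor), compound 1 gives 1.5 nM and compound 2 gives 1.7 nM. Among the compounds with values here, compound 2 carries the higher of the two numbers, but its only neighbour is within the scatter: a 1.1-fold higher number from compound 1 to compound 2 (0.05 log units; within the scatter) for chloro in place of hydrogen on an aromatic carbon, so the two cannot be ranked.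

Compound 3, `CCCCNC(=O)OC[C@H](C1CC1)n1cc(Cl)nc(Nc2cc(C)c(OC)nc2C)c1=O`, is not yet measured. It differs from compound 2 by butyl in place of 2,4-dichlorophenyl on an amide-type nitrogen. Within the data shown here, no measured step touches the substituent on the amide-type nitrogen; the single known step, a 1.1-fold higher number from compound 1 to compound 2 (0.05 log units; within the scatter), concerns a chloro on the ring that now leaves and was flat. The expectation therefore rests on little, and a modest weakening is assumed rather than derived.

Compound 3 is expected to give 5 nM, within 1.2 nM to 25 nM, a step of a 2.9-fold higher number from compound 2 to compound 3 (0.47 log units; beyond the scatter).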

Compound 3, half-maximal inhibitory concentration: 4.7 nM
Compound 3: middle estimate off by 1.1-fold (0.03 log units), on the high side; low and high end bracket the measured number.
By their numbers in this assay, from the lowest: compounds 1 and 2 (each within the scatter of the next); then compound 3.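

Within the data shown here, the carbamate nitrogen substituent is the first place where a change registers beyond the scatter: in this assay, butyl in place of 2,4-dichlorophenyl gives a 2.8-fold higher number from compound 2 to compound 3 (0.44 log units; beyond the scatter), and butyl in place of 2-chlorophenyl gives a 3.1-fold higher number from compound 1 to compound 3 (0.50 log units; beyond the scatter). Both steps are modest, and compound 3 still gives 4.7 nM, so an aromatic ring on this amide-type nitrogen is not required for activity in the nanomolar range. Nothing available explains the difference between the chlorophenyl groups and butyl.

The compounds shown leave open whether the modest loss follows the removal of the aromatic ring or the nature of the butyl chain itself. An unsubstituted phenyl, a benzyl, a cyclohexyl or a longer chain such as hexyl on this nitrogen would help to separate these readings.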